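The source may report more compounds than this note shows. Statements on the series, on what has been measured and on what is new or still open speak of the compounds shown alone.

Measured in an ADME assay on microsomes from liver (Mus musculus) for metabolic stability; a higher number here means faster removal of the compound, a lower number slower removal:
Compound 1 `O=C(Nc1ccc(Cl)cc1)C(=O)N1CCC(c2ccnc3ccc(F)cc23)CC1`: 97 mL.min-1.g-1
Compound 2 `O=C(Nc1ccc(Cl)cc1F)C(=O)N1CCC(c2ccnc3ccc(F)cc23)CC1`: 108 mL.min-1.g-1

Compound 2 lies within the scatter of compound 1, so the two cannot be ranked. Compound 3 `N#Cc1ccc(NC(=O)C(=O)N2CCC(c3ccnc4ccc(F)cc34)CC2)cc1` is the next to be read: 4-cyanophenyl in place of 4-chloro-2-fluorophenyl on an amide-type nitrogen. Going by the values given here, the only measured step, a 1.1-fold higher number from compound 1 to compound 2 (0.05 log units; within the scatter), is fluoro in place of hydrogen on an aromatic carbon. Among the compounds with values here, it covers only part of the change, and no measured step covers the entry of 4-cyanophenyl. A modest downward move is therefore expected, held loosely, and the estimated step is a 1.4-fold lower number from compound 2 to compound 3 (0.16 log units; within the scatter). Compound 3 is estimated at 75 mL.min-1.g-1, with an expected range of 38 mL.min-1.g-1 to 130 mL.min-1.g-1.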

Compound 3, intrinsic clearance in microsomes: 28 mL.min-1.g-1
Beside the measured number, compound 3's estimate is 2.7-fold (0.43 log units) above it; measured number outside the range, below it.
By their numbers in this assay, from the lowest: compound 3; then compounds 1 and 2 (each within the scatter of the next).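

In this assay the group on the amide-type nitrogen proves able to move the number: 4-cyanophenyl in place of 4-chloro-2-fluorophenyl gives a 3.9-fold lower number from compound 2 to compound 3 (0.59 log units; beyond the scatter) and cyano in place of chloro gives a 3.5-fold lower number from compound 1 to compound 3 (0.54 log units; beyond the scatter) while the fluoro step stayed within the scatter. Both steps lie beyond the scatter, so the shift appears from either starting compound. Nothing available explains the shift.

Still open, on these data alone, is whether the shift is specific to the nitrile, or also follows other replacements of chloro, such as an amine or a carboxylic acid.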